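Acetyl for Ethyl on the Shared Phenol Core

A few compounds are considered here, and "the series" means these few. Any claim that something is new, unique, unknown or untested is made for them only; others in the source may bear on it.

Compound 1: `CCCCCCCCC(=O)NCc1cc(Br)c(O)c(OC)c1` — 252 nM in an assay on HEK293 cells for inhibition of transient receptor potential cation channel subfamily V member 1 (Homo sapiens); on this read-out lower numbers stand for stronger inhibition and higher numbers for weaker inhibition
Compound 2: `CCCCCCCCC(=O)NCc1cc(CC)c(O)c(OC)c1` — 355 nM in this assay

Of the compounds shown here, two have been measured in this assay. Compound 1 gives 252 nM and compound 2 gives 355 nM; the step of a 1.4-fold higher number from compound 1 to compound 2 (0.15 log units; within the scatter) lies within the scatter, so neither compound can be called the more potent. Compound 2 therefore stands at the highest of the two numbers, with compound 1 as its nearest neighbour, and the two are not separable.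

Compound 3, `CCCCCCCCC(=O)NCc1cc(OC)c(O)c(C(C)=O)c1`, has not yet been measured. It differs from compound 2 by acetyl in place of ethyl on an aromatic carbon. For the measured compounds named here, no measured step touches this change: the only step at hand exchanges bromo for ethyl at the same position, and it stayed within the scatter. On this basis the step to compound 3 is expected to be modest, with no direction firmly indicated, and the estimate for compound 3 in this assay is 400 nM (range 150 nM to 1100 nM). The expected step is a 1.1-fold higher number from compound 2 to compound 3 (0.05 log units; within the scatter).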

Compound 3, half-maximal inhibitory concentration: 10400 nM
Compound 3: middle estimate off by 26-fold (1.41 log units), on the low side, outside the stated range (above it).
By their numbers in this assay, from the lowest: compounds 1 and 2 (each within the scatter of the next); then compound 3.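

In this assay the position ortho to the hydroxy group proves not to be indifferent to what it carries: acetyl in place of ethyl gives a 29-fold higher number from compound 2 to compound 3 (1.47 log units; beyond the scatter) and acetyl in place of bromo gives a 41-fold higher number from compound 1 to compound 3 (1.62 log units; beyond the scatter), which makes compound 3 the weakest of the three. The exchange of bromo for ethyl had given only a 1.4-fold higher number from compound 1 to compound 2 (0.15 log units; within the scatter) and had separated nothing, so the earlier pair gave no sign that this position could respond so strongly. What enters with acetyl in place of ethyl is one oxygen, one hydrogen-bond acceptor and one double bond outside aromatic rings, but no measurement at hand bears on which of these, if any, lies behind the result.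

The three compounds leave open whether the large step follows the carbonyl itself, a question that a hydroxymethyl group, a nitrile or a methyl ester at this position could help to settle. On these data alone, it is equally open whether an amine or a carboxylic acid there would stand nearer compound 2 or nearer compound 3.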